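The source may hold more compounds than are shown below. What is called first, only, known or untested is meant among the compounds shown, and "the series" means these compounds.

Measured compounds in an ADME assay on RAW264.7 cells (Mus musculus) for cytotoxicity, read by MTT assay, with a stated time of 48 h, tested at 50 uM; on this read-out lower numbers stand for less inhibition and higher numbers for more inhibition at the one concentration tested (going by the name of the read-out):
compound 1 `NC(=O)c1c(NC(=O)c2ccc(Cl)cc2)sc2c1CCN(C(=O)c1ccccc1)C2`, 42.5%
compound 2 `CN1CCc2c(sc(NC(=O)c3ccc(Cl)cc3)c2C(N)=O)C1`, 38.5%
compound 3 `CC(C)(C)OC(=O)N1CCc2c(sc(NC(=O)c3ccc(Cl)cc3)c2C(N)=O)C1`, 37.3%

Compound 1 gives the highest of the three numbers, though its steps to the other two are small: a number 4 percentage points lower from compound 1 to compound 2 (within the scatter) and a number 5.2 percentage points lower from compound 1 to compound 3 (within the scatter). Between compound 2 and compound 3 the step is a number 1.2 percentage points lower from compound 2 to compound 3 (within the scatter). Among the measured compounds shown here, all three measured changes sit on the amine nitrogen in the ring or on the carbonyl carbon attached to it, and none of them moves the read-out beyond the scatter; the measured series so far occupies a narrow band.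

Compound 4 `NC(=O)c1c(NC(=O)c2ccc(OCc3ccccc3)cc2)sc2c1CCN(C(=O)c1ccccc1)C2` differs from compound 1 at another place: benzyloxy in place of chloro on an aromatic carbon. For the measured compounds named here, no measured step touches this aromatic carbon, so the three steps above offer no direct guide to this change; they show only that the series has been flat under the changes tried so far. On that basis the expectation for compound 4 in this assay is a step of a number 0.5 percentage points higher from compound 1 to compound 4 (within the scatter), that is, no movement beyond the scatter, with a range widened to allow for an untested kind of change. Compound 4 is therefore estimated at 43%, expected to fall between 28% and 58%.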

Compound 4, a percentage reported as inhibition, at one concentration (the size of the read-out at that concentration, not a potency): 13.7%
Beside the measured number, compound 4's estimate is 29.3 percentage points above it; the whole stated range lies above it.
By their numbers in this assay, from the lowest: compound 4; then compounds 3, 2 and 1 (each within the scatter of the next).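

In this assay, among the compounds shown here, the aromatic carbon para to a large group is the first place where a change moves the read-out beyond the scatter: benzyloxy in place of chloro gives a number 28.8 percentage points lower from compound 1 to compound 4 (beyond the scatter) and so separates this position from the amine nitrogen in the ring and its attached carbonyl carbon, where the steps among compounds 1, 2 and 3 all stay within the scatter. The change replaces a single chlorine with a group that adds an oxygen and a six-membered aromatic ring of carbon only, and this one step cannot show which of these parts goes with the lower number. No available evidence bears on the reason for the step.

Open, going by these compounds, is how the read-out responds to smaller or differently built groups on this aromatic carbon, such as methoxy, a hydroxyl, an amine or a phenyl ring joined directly, which would help separate the oxygen link from the terminal ring. Also open, on these data alone, is whether benzyloxy gives a step of similar size when the benzoyl on the ring nitrogen is replaced by methyl or tert-butoxycarbonyl.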